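Replacing 8-hydroxyquinolin-2-yl with (1H-indol-5-yl)methyl

A few compounds are considered here, and "the series" means these few. Any claim that something is new, unique, unknown or untested is made for them only; others in the source may bear on it.

Measured so far in a functional assay on K562 cells (Homo sapiens) for inhibition, read by trypan blue exclusion, with a stated time of 72 h (on this read-out higher numbers stand for weaker inhibition and lower numbers for stronger inhibition), are three compounds:
- compound 1 `Cn1c(=O)c(S(=O)(=O)c2ccc(F)cc2F)cc2cnc(Nc3ccc4[nH]c(C(=O)O)cc4c3)nc21` gives 10000 nM
- compound 2 `Cn1c(=O)c(S(=O)(=O)c2ccc(F)cc2F)cc2cnc(Nc3ccncn3)nc21` gives 30000 nM
- compound 3 `Cn1c(=O)c(S(=O)(=O)c2ccc(F)cc2F)cc2cnc(Nc3ccc4cccc(O)c4n3)nc21` gives 5000 nM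

Compound 3 stands at 5000 nM and so lies within the scatter of compound 1 at 10000 nM but clear of compound 2 at 30000 nM in this assay on these numbers. Compound 4 `Cn1c(=O)c(S(=O)(=O)c2ccc(F)cc2F)cc2cnc(NCc3ccc4[nH]ccc4c3)nc21` has not yet been measured. It differs from compound 3 in one place, on a nitrogen on an aromatic ring, where (1H-indol-5-yl)methyl stands in place of 8-hydroxyquinolin-2-yl ((1H-indol-5-yl)methyl in place of 8-hydroxyquinolin-2-yl on a nitrogen on an aromatic ring).

Three measured steps change the group at this same place. They are a 6.0-fold lower number from compound 2 to compound 3 (0.78 log units; beyond the scatter) and a 3.0-fold higher number from compound 1 to compound 2 (0.48 log units; beyond the scatter), both modest, and a 2.0-fold lower number from compound 1 to compound 3 (0.30 log units; within the scatter) within the scatter. None of them involves (1H-indol-5-yl)methyl, so they offer only a rough guide to size and none to direction. Since the steps seen here stay modest, no large change is foreseen, though a modest one either way remains possible. The expected change is a 1.2-fold higher number from compound 3 to compound 4 (0.08 log units; within the scatter) and so none beyond the scatter. For compound 4 the estimated value is 6000 nM with an expected range from 1500 nM to 25000 nM in this assay as the assay of record.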

Compound 4, half-maximal inhibitory concentration: 75000 nM
Compound 4: the middle estimate sits 13-fold (1.10 log units) below what was measured; the whole stated range lies below it.
By their numbers in this assay, from the lowest: compounds 3 and 1 (each within the scatter of the next); then compound 2; then compound 4.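

In this assay, this position on the nitrogen proves capable of a large step, a 15-fold higher number from compound 3 to compound 4 (1.18 log units; beyond the scatter), whereas the earlier changes here had stayed modest or within the scatter. The (1H-indol-5-yl)methyl group also falls behind the other two groups, with a 2.5-fold higher number from compound 2 to compound 4 (0.40 log units; beyond the scatter) and a 7.5-fold higher number from compound 1 to compound 4 (0.88 log units; beyond the scatter), which makes compound 4 the weakest of the four; it is also the only one of the four whose ring system reaches the nitrogen through a methyl link rather than directly. The data shown offer no measurement that bears on why the number rose.

On these data alone, compound 1 and compound 4 differ in both the carboxy group and the methyl link, so these compounds cannot separate the two, and the effect of the link alone remains open without 1H-indol-5-yl set directly on the nitrogen for comparison. Also open, as far as these compounds go, is how this assay would read a longer chain in place of the methyl link, or a carboxylic acid or an amine on the (1H-indol-5-yl)methyl group.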